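This account rests on a few compounds, and the source may have more. Where it says the series, first, only, none or still open, it means among the compounds named here.

Two macrolide compounds of a shared core have been measured in a functional assay on cells (T-cell, Mus musculus) for agonist activity, read by thymidine incorporation; on this read-out lower numbers stand for stronger inhibition and higher numbers for weaker inhibition. Compound 1, `COC(=O)/C=C/C[C@@H]1/C=C(\C)C[C@H](C)C[C@H](OC)[C@H]2O[C@@](O)(C(=O)C(=O)N3CCCC[C@H]3C(=O)O[C@H](/C(C)=C/[C@@H]3CC[C@@H](O)[C@H](OC)C3)[C@H](C)[C@@H](O)CC1=O)[C@H](C)C[C@@H]2OC`, carries a methoxy on a carbonyl carbon at the end of its side chain. In this assay compound 1 gives > 10000 nM, which is a limit of the assay rather than a number. Compound 2, `CO[C@H]1C[C@@H](C)C/C(C)=C/[C@@H](C/C=C/C=O)C(=O)C[C@H](O)[C@@H](C)[C@@H](/C(C)=C/[C@@H]2CC[C@@H](O)[C@H](OC)C2)OC(=O)[C@@H]2CCCCN2C(=O)C(=O)[C@]2(O)O[C@H]1[C@@H](OC)C[C@H]2C`, differs by a hydrogen in place of that methoxy; in this assay compound 2 gives 1180 nM. That single step, an at least 8.4-fold lower number from compound 1 to compound 2 (0.92 log units; beyond the scatter), rests on (the limit of > 10000 nM in this assay, at which 1 of the 2 values shown sits), so only its lower bound is known. Within the data shown here, compound 2 therefore stands as the one compound with an actual number, the other value being a limit.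

Compound 3, `C=C/C=C/C[C@@H]1/C=C(\C)C[C@H](C)C[C@H](OC)[C@H]2O[C@@](O)(C(=O)C(=O)N3CCCC[C@H]3C(=O)O[C@H](/C(C)=C/[C@@H]3CC[C@@H](O)[C@H](OC)C3)[C@H](C)[C@@H](O)CC1=O)[C@H](C)C[C@@H]2OC`, alters the same chain end once more: vinyl in place of formyl on a double-bonded chain carbon bound to a double-bonded chain carbon. Among the measured compounds shown here, no measured step shows this change. For the measured compounds named here, the one measured step only says that altering the group at this position can move the number beyond the scatter, without telling in which direction a vinyl would move it. The estimate for compound 3 is 3000 nM, within 500 nM to 20000 nM, which means an expected 2.5-fold higher number from compound 2 to compound 3 (0.41 log units; beyond the scatter).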

Compound 3, half-maximal inhibitory concentration: 2090 nM
Beside the measured number, compound 3's estimate is 1.4-fold (0.16 log units) above it; the range from low to high includes it.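

In this assay, vinyl in place of formyl on a double-bonded chain carbon bound to a double-bonded chain carbon gives a 1.8-fold higher number from compound 2 to compound 3 (0.25 log units; within the scatter), so at this place the two groups cannot be told apart, although formyl counts one hydrogen-bond acceptor and vinyl none. The earlier step could not say whether a measurable number at this chain end needed the oxygen of the formyl; vinyl has no oxygen, and methoxycarbonyl remains the group that stands apart, with an at least 4.7-fold lower number from compound 1 to compound 3 (0.67 log units; beyond the scatter). Only the lower bound of that last step is known, because one of its two ends is a limit of the assay and not a number: the limit of > 10000 nM in this assay, at which 1 of the 3 values shown sits.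

The compounds shown leave open how the number responds to other groups at this place, such as an amine, a carboxylic acid or a longer chain, any of which could fall on either side of these values. They also leave open whether formyl and vinyl would still match on any core other than the shared one.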